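A Single Aryl Swap in a Level Solubility Series

The source may report more compounds than this note shows. Statements on the series, on what has been measured and on what is new or still open speak of the compounds shown alone.

In a physicochemical assay for solubility, at pH 1.1 (a lower number here means a less soluble compound, a higher number a more soluble compound), compound 1 `CCCN(Cc1ccc(OCCn2c(=O)ccn(C)c2=O)c(C)c1)C(CC(=O)O)c1ccc(Cl)cc1` gives 3000000 nM and compound 2 `CCCCN(Cc1ccc(OCCn2c(=O)ccn(C)c2=O)c(OC)c1)C(CC(=O)O)c1ccc(Cl)cc1` gives 3000000 nM while compound 3 `COc1cc(CN(CC(C)C)C(CC(=O)O)c2ccc3c(c2)CCO3)ccc1OCCN1C(=O)CCC1=O` gives 3000000 nM as well, so compound 3 stands level with both. Compound 4 `COc1cc(CN(CC(C)C)C(CC(=O)O)c2ccc(Cl)c(F)c2)ccc1OCCN1C(=O)CCC1=O` departs from compound 3 through one change a group of 8 heavy atoms (6 carbon, 1 fluorine, 1 chlorine; one six-membered aromatic ring of carbon only) in place of a group of 9 heavy atoms (8 carbon, 1 oxygen; one five-membered non-aromatic ring with 1 hetero atom, one six-membered aromatic ring of carbon only), on a saturated chain carbon bound to an amine nitrogen and a saturated chain carbon that brings in 4-chloro-3-fluorophenyl on a saturated chain carbon bound to an amine nitrogen and a saturated chain carbon. Among the compounds with values here, no two measured compounds differ in one place alone. The expectation therefore rests on compound 3 at 3000000 nM and no move beyond the scatter is expected in this assay in either direction. The expected step of no change at the digits printed from compound 3 to compound 4 (within the scatter) stays within the scatter. Compound 4 is expected at 3000000 nM in this assay with an estimated range of 1500000 nM to 4000000 nM around it.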

Compound 4, solubility: 3000000 nM
Beside the measured number, compound 4's estimate shows no gap at the digits printed; measured number inside the range.
By their numbers in this assay, from the lowest: compounds 1, 2, 3 and 4 (each within the scatter of the next).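

In this assay, within the data shown here, the exchange at this position gives no change at the digits printed from compound 3 to compound 4 (within the scatter), the first comparison here of compounds that differ in one place. On the saturated chain carbon bound to an amine nitrogen and a saturated chain carbon, 4-chloro-3-fluorophenyl can thus replace the ring-fused group of compound 3 without a measurable shift in this pair. Nothing available here accounts for this outcome.

Going by these compounds, it remains open whether a pyridine ring at this position would read the same, and whether a primary amide could stand in place of the carboxylic acid.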